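The source may hold more compounds than are shown below. What is called first, only, known or untested is meant among the compounds shown, and "the series" means these compounds.

Working notes on the series. Compound 1 `COC(=O)[C@@]1(C)CCC=C2[C@@H]1CC[C@@H](C)[C@]2(C)Cc1c[nH]c2ccc(C(F)(F)F)cc12` and compound 2 `COC(=O)[C@@]1(C)CC[C@@H]2C3=C1CC[C@@H](C)[C@]3(C)C[C@@H]1c3ccccc3N[C@H]21` share the same core carrying a methyl ester, and both have been tested in a functional assay on HBL-100 cells (Homo sapiens) for inhibition, read by sulforhodamine B assay, with a stated time of 48 h; on this read-out higher numbers stand for weaker inhibition of growth and lower numbers for stronger inhibition of growth. In this assay compound 1 gives 15000 nM, while compound 2 gives 78000 nM, the higher of the two numbers; the gap between the two lies beyond the usual scatter, so compound 1 inhibits growth more strongly than compound 2.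

Compound 3 `COC(=O)[C@@]1(C)CC[C@@H]2C3=C1CC[C@@H](C)[C@]3(C)C[C@@H]1c3cc(C)ccc3N[C@H]21` is the next member and has not yet been measured. It differs from compound 2 by methyl in place of hydrogen on an aromatic carbon. No comparable exchange of hydrogen for methyl is available among the measured compounds, so nothing in the measured pair tells which way such a change moves this assay. For this reason only a small step is expected from compound 2 to compound 3, a 1.3-fold lower number from compound 2 to compound 3 (0.11 log units; within the scatter), not clearly beyond the scatter in either direction. Compound 3 is accordingly estimated at 60000 nM in this assay, with a plausible range from 20000 nM to 180000 nM.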

Compound 3, concentration for 50% growth inhibition: 15000 nM
Beside the measured number, compound 3's estimate is 4.0-fold (0.60 log units) above it, outside the stated range (below it).
By their numbers in this assay, from the lowest: compounds 1 and 3 (each within the scatter of the next); then compound 2.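

In this assay the exchange of hydrogen for methyl on this aromatic carbon, meta to a fused ring and para to a fused ring, brings a 5.2-fold lower number from compound 2 to compound 3 (0.72 log units; beyond the scatter) and so moves the read-out towards stronger inhibition of growth. Among these compounds, this is the first change at a single place that can be read, and it shows that this position of the shared core is not silent: one added carbon is enough for a step beyond the scatter. No measurement is at hand that explains this step.

Whether the step is specific to methyl stays open, as a longer chain such as ethyl, a methoxy group or a chlorine atom on this carbon is not among the compounds shown. On these data alone, the other carbons of this aromatic ring carry only hydrogen in compound 2 and compound 3, so it also stays open whether methyl would act the same way elsewhere on the ring.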